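Series notes: fluoro-to-iodo swap on the shared core

The source may hold more compounds than are shown below. What is called first, only, known or untested is meant among the compounds shown, and "the series" means these compounds.

Two compounds carry a measured value in a functional assay on HeLa cells (Homo sapiens) for antiproliferative activity, read by cell counting, with a stated time of 72 h; on this read-out higher numbers stand for weaker inhibition and lower numbers for stronger inhibition. Compound 1 `C#C[C@@]1(O)[C@@H](CO)O[C@@H](n2cnc3c(-c4ccccc4)ncnc32)[C@@H]1O` gives only a limit in this assay, > 250000 nM, which marks the limit of > 250000 nM in this assay, at which 1 of the 2 values shown sits, rather than a number. For the measured compounds named here, compound 2 `C#C[C@@]1(O)[C@@H](CO)O[C@@H](n2cc(F)c3c(N)ncnc32)[C@@H]1O` gives 150 nM in this assay, and this is the only number in the set. Compound 2 therefore stands as the single measured point from which the next step is taken. Going by the values given here, no step between two measured compounds is available, so the size of a single change in this assay has not yet been seen.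

Compound 3 `C#C[C@@]1(O)[C@@H](CO)O[C@@H](n2cc(I)c3c(N)ncnc32)[C@@H]1O` is the next compound. It differs from compound 2 by iodo in place of fluoro on an aromatic carbon. Nothing in the measured data shows how an exchange of one halogen for another at this place moves the read-out, and no cause can be assigned to it. The step is expected to be modest, in either direction, and most likely within the range that repeated measurements would cover: the expected step is a 2.0-fold higher number from compound 2 to compound 3 (0.30 log units; within the scatter). Compound 3 is estimated to give 300 nM in this assay, with a range from 60 nM to 1500 nM.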

Compound 3, half-maximal inhibitory concentration: 180 nM
Compound 3: the middle estimate sits 1.7-fold (0.22 log units) above what was measured, within the range that was stated.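

In this assay, the first single change seen on the shared core is a 1.2-fold higher number from compound 2 to compound 3 (0.08 log units; within the scatter), so iodo in place of fluoro on this aromatic carbon gives two values that the read-out cannot tell apart. The place, on the five-membered aromatic ring with 1 nitrogen and two ring bonds from the ring nitrogen, thus carries either halogen with antiproliferative values of the same order, something the lone value of compound 2 could not show. Nothing measured here gives a reason for this result.

Going by these compounds, two halogens are a narrow sample of this place, and it remains open whether the read-out stays the same with a chloro or bromo group, a methyl, a nitrile, an amine or a longer chain there, or with hydrogen in place of any halogen. On these data alone, compound 1 gives > 250000 nM, which is a limit and not a number, and it offers no readable step, so the parts in which it differs from the other compounds also remain open.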